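The source may hold more compounds than are shown below. What is called first, only, known or untested is meant among the compounds shown, and "the series" means these compounds.

In an ADME assay on BaF3 cells (Mus musculus) for cytotoxicity (a lower number here means that less compound is needed, a higher number that more compound is needed for the effect), compound 1, `NC(=O)CCn1ccc2c(Nc3ccc(OC(F)(F)F)cc3)ncnc21`, is reported only as a limit of the assay, > 10000 nM. Compound 2, `CS(=O)(=O)c1cccc(-c2cc(Nc3ccc(OC(F)(F)F)cc3)ncn2)c1`, likewise gives in this assay only a limit, > 10000 nM. Compound 2 therefore stands at the limit of > 10000 nM in this assay, at which 2 of the 2 values shown sit, with no number that would let it be ranked against compound 1. Compound 3, `Nc1cccc(-c2cc(Nc3ccc(OC(F)(F)F)cc3)ncn2)c1`, remains to be measured in this assay. It differs from compound 2 by amino in place of methylsulfonyl on an aromatic carbon. Among the measured compounds shown here, no step between two measured compounds is available in this assay, so there is no measured precedent for the size of such a change. Since both measured compounds sit at the limit, compound 3 is expected to remain there as well. For compound 3 the step that this estimate implies, a step that the limit leaves unreadable from compound 2 to compound 3, is expected to be none beyond the scatter. Compound 3 is estimated at 15000 nM in this assay, with a range from 5000 nM to 50000 nM.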

Compound 3, half-maximal effective concentration: > 10000 nM
Compound 3: only a limit was reported; the forecaster's own chance of this, stated with the estimate: 80%; the middle value lies beyond the limit too.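

In this assay compound 3 gives only a limit, > 10000 nM. Among the compounds shown here, with compound 2 also reported only as a limit, no step between compound 2 and compound 3 can be read. The compounds shown leave open how far beyond the limit any of them lies, and whether amino or methylsulfonyl makes any difference.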